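The source may report more compounds than this note shows. Statements on the series, on what has been measured and on what is new or still open speak of the compounds shown alone.

Compound 1 `COc1cc(-c2nnc3n2NC(c2ccco2)C(C(=O)c2cccc(Br)c2)S3)cc(OC)c1OC`: in a functional assay on HepG2 cells (Homo sapiens) for cytotoxicity, read by MTT assay, with a stated time of 48 h (a lower number here means a stronger inhibitor, a higher number a weaker inhibitor), compound 1 gives > 100000 nM
Compound 2 `COc1ccc(C(=O)C2Sc3nnc(-c4cc(OC)c(OC)c(OC)c4)n3NC2c2cccs2)cc1`: compound 2 gives 68000 nM
Compound 3 `COc1cc(-c2nnc3n2NC(c2cccs2)C(C(=O)c2ccc(Cl)cc2)S3)cc(OC)c1OC`: compound 3 gives 13200 nM

The value of compound 1 is not a number but a limit of this assay (the limit of > 100000 nM in this assay, at which 1 of the 3 values shown sits), so compound 1 stands only as weaker than that boundary, with no measured number of its own. Compound 4 `COc1cc(-c2nnc3n2NC(c2ccco2)C(C(=O)c2ccc(Br)cc2)S3)cc(OC)c1OC` keeps every atom of compound 1 and differs only in one arrangement: 4-bromophenyl in place of 3-bromophenyl on a carbonyl carbon.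

The single measured step among these compounds is a 5.2-fold lower number from compound 2 to compound 3 (0.71 log units; beyond the scatter), a modest change that rests on chloro in place of methoxy on an aromatic carbon. Going by the values given here, that change is of a different kind and at a different ring from the one between compound 1 and compound 4, so it offers no direct guide; no measured step bears on a shift of bromine from one position of the phenyl ring to another.

Among the compounds with values here, with only a limit for compound 1 and no matching step, compound 4 is estimated at 70000 nM, within a wide range from 15000 nM to 300000 nM. This estimate corresponds to an expected step of an at least 1.4-fold lower number from compound 1 to compound 4 (0.15 log units; that floor lies within the scatter), with a real chance that compound 4 again returns only a limit.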

Compound 4, half-maximal inhibitory concentration: > 100000 nM
Compound 4: no number, only a limit; the forecaster's own chance of this, stated with the estimate: 45%; middle value at least 1.4-fold (0.15 log units) from the limit.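

In this assay, going by these compounds alone, compound 1 and compound 4 each return only a limit, and no step between them can be read. The compounds shown leave open how far either compound lies past that limit, and whether 4-bromophenyl in place of 3-bromophenyl changes the result at all.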